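The source may report more compounds than this note shows. Statements on the series, on what has been measured and on what is new or still open speak of the compounds shown alone.

Working notes on the series. Three sulfonamides share one core and differ only in the group on the sulfonyl sulfur. Compound 1 `Cc1noc(C)c1S(=O)(=O)N1CCC(N2CCC(C)CC2)CC1` carries 3,5-dimethyl-1,2-oxazol-4-yl; in an ADME assay on HCT-116 cells (Homo sapiens) for cytotoxicity, read by CellTiter-Glo, with a stated time of 72 h (a lower number here means a stronger inhibitor, a higher number a weaker inhibitor), compound 1 returns only a limit, > 10000 nM. Compound 2 `CC1CCN(C2CCN(S(=O)(=O)c3nccn3C)CC2)CC1` carries 1-methyl-1H-imidazol-2-yl, and in this assay compound 2 likewise returns a limit, > 10000 nM. Compound 3 `CC1CCN(C2CCN(S(=O)(=O)c3cccc(Cl)c3)CC2)CC1` carries 3-chlorophenyl; in this assay compound 3 stops at a limit, > 5000 nM. Hence a step that the two limits leave unreadable from compound 1 to compound 2, a step that the two limits leave unreadable from compound 1 to compound 3 and a step that the two limits leave unreadable from compound 2 to compound 3 cannot be read, and compound 3 stands nowhere apart from the rest: every value so far sits either at the limit of > 10000 nM in this assay, at which 2 of the 3 values shown sit, or at the limit of > 5000 nM in this assay, at which 1 of the 3 values shown sits.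

Compound 4 `CC1CCN(C2CCN(S(=O)(=O)c3cc(Cl)cc(Cl)c3)CC2)CC1` differs from compound 3 by a single change: chloro in place of hydrogen on an aromatic carbon. Among the measured compounds shown here, no measured step bears on this change, and the steps that exist, all running between limits, give no readable size. The expectation is therefore no step beyond the scatter, a step that the limit leaves unreadable from compound 3 to compound 4. Compound 4 is estimated in this assay at 15000 nM, within 4000 nM to 60000 nM, most probably reported again as a limit.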

Compound 4, half-maximal inhibitory concentration: > 5000 nM
Compound 4: a limit, no number; the forecaster's own chance of this, stated with the estimate: 80%; the middle value does not contradict the limit.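

In this assay compound 4 returns only a limit, > 5000 nM, so its steps from compound 1, compound 2 and compound 3 cannot be read. The compounds shown leave open whether any group on the sulfonyl sulfur gives a measurable value in this assay.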